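The source may report more compounds than this note shows. Statements on the series, on what has been measured and on what is new or still open speak of the compounds shown alone.

Measured so far:
compound 1, `Cc1ccc(-c2cnn3c(NCc4ccccn4)cc(C)nc23)cc1`: < 5000 nM
compound 2, `Cc1cc(N(C)Cc2ccccn2)n2nc(C)c(-c3ccccc3)c2n1`: 17500 nM
compound 3, `Cc1cc(NCc2nccs2)n2nc(C)c(-c3ccccc3)c2n1`: 108000 nM

In a physicochemical assay for solubility, read by HPLC, using the shake flask method, measured as kinetic solubility, with a stated time of 2 h, at pH 7.4 (a lower number here means a less soluble compound, a higher number a more soluble compound), compound 1 gives only < 5000 nM, which is a limit of the assay rather than a number. That puts compound 1 at the low end of the three values shown, where (the limit of < 5000 nM in this assay, at which 1 of the 3 values shown sits). Compound 2 and compound 3 both give measured numbers, with compound 3 the higher of the two.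

Compound 4, `Cc1cc(NCc2ccccn2)n2ncc(-c3ccc(F)c(Cl)c3)c2n1`, differs from compound 1 by 3-chloro-4-fluorophenyl in place of 4-methylphenyl on an aromatic carbon. Among the measured compounds shown here, no measured pair shows the effect of this change, so the expected step in this assay is none beyond the scatter. Compound 4 is therefore estimated at 3000 nM, within 800 nM to 10000 nM, an expected step that the limit leaves unreadable from compound 1 to compound 4 from compound 1, and most likely again reported as a limit.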

Compound 4, solubility: < 5000 nM
Compound 4 was reported as a limit; the forecaster's own chance of this, stated with the estimate: 60%; the middle value lies beyond the limit too.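

No step can be read between compound 1 and compound 4, because both are reported only as a limit: the limit of < 5000 nM in this assay, at which 2 of the 4 values shown sit.

The compounds shown leave open how 3-chloro-4-fluorophenyl in place of 4-methylphenyl changes solubility, and how far either compound's true solubility lies from that limit.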